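A few compounds are considered here, and "the series" means these few. Any claim that something is new, unique, unknown or untested is made for them only; others in the source may bear on it.

Measured so far in an assay on isolated protein for displacement of a labelled ligand from Type-2 angiotensin II receptor (Rattus norvegicus); a higher number here means a weaker inhibitor, a lower number a stronger inhibitor:
compound 1, `CCCc1cc(Cn2c(CC)nc3c(C)cc(C)nc32)cc(CCC)c1OC(C(=O)O)c1ccc(CC)cc1`: 240 nM
compound 2, `CCCc1cc(Cn2c(CC)nc3c(C)cc(C)nc32)cc(CCC)c1OC(C(=O)O)c1ccccc1`: 2600 nM

Compound 2 stands highest of the two numbers in this assay, its nearest neighbour being compound 1 with an ethyl on the aromatic carbon where compound 2 carries hydrogen. Within the data shown here, the only measured step, an 11-fold higher number from compound 1 to compound 2 (1.03 log units; beyond the scatter), shows that adding a carbon substituent to that ring changed the number greatly. Compound 3, `CCCc1cc(Cn2c(CC)nc3c(C)cc(C)nc32)cc(CCC)c1OC(C(=O)O)c1cccc(Oc2ccccc2)c1`, differs from compound 2 by phenoxy in place of hydrogen on an aromatic carbon. The earlier step bears on this change only loosely, since the entering group is larger and sits at a different place on the ring, so the direction is taken from it but the size is uncertain. He expects a step of a 3.3-fold lower number from compound 2 to compound 3 (0.51 log units; beyond the scatter) toward a lower number. Compound 3 is estimated at 800 nM, with a range from 150 nM to 4000 nM.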

Compound 3, half-maximal inhibitory concentration: 1600 nM
Beside the measured number, compound 3's estimate is 2.0-fold (0.30 log units) below it; low and high end bracket the measured number.
By their numbers in this assay, from the lowest: compound 1; then compounds 3 and 2 (each within the scatter of the next).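

In this assay, phenoxy in place of hydrogen gives a 1.6-fold lower number from compound 2 to compound 3 (0.21 log units; within the scatter), so at this place, meta to a large group, a substituent of seven heavy atoms leaves compound 3 indistinguishable from compound 2. Entry of a carbon-bearing group on this ring therefore does not always go with a large step: ethyl gave an 11-fold higher number from compound 1 to compound 2 (1.03 log units; beyond the scatter), but it differs from phenoxy in both group and place on the ring. No measurement shown here explains this contrast.

The compounds shown leave open whether the large step belongs to the ethyl group or to its place on the ring. Phenoxy at the place of ethyl, or ethyl, methoxy or a chlorine atom at the place of phenoxy, would begin to separate the two.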